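Working notes: from compound 1 to compound 3

The source may hold more compounds than are shown below. What is called first, only, known or untested is meant among the compounds shown, and "the series" means these compounds.

- Compound 1 `Cc1nn(-c2ccccc2)c2nc(OCc3ccccc3F)c(-c3nc(N)c(N(C)C)c(N)n3)cc12`: 1100 nM
- Compound 2 `Cc1nn(-c2ccccc2)c2nc(OCc3ccccc3F)c(-c3nc(N)c(NC(=O)OC4CCCC4)c(N)n3)cc12`: > 100000 nM (a limit)

Within the data shown here, in a functional assay on aorta (Rattus norvegicus, strain Sprague-Dawley) (a lower number here means that less compound is needed, a higher number that more compound is needed for the effect), compound 1, at 1100 nM, holds the only true number so far. The entry for compound 2 is a limit. Compound 3 `Cc1nn(-c2ccccc2)c2nc(OCc3ccccc3F)c(-c3nc(N)c4c(n3)[nH]c(=O)n4C)cc12` carries a group of 12 heavy atoms (6 carbon, 5 nitrogen, 1 oxygen; one five-membered aromatic ring with 2 hetero atoms, one six-membered aromatic ring with 2 hetero atoms) in place of a group of 11 heavy atoms (6 carbon, 5 nitrogen; one six-membered aromatic ring with 2 hetero atoms), on an aromatic carbon. Among the measured compounds shown here, the one measured step, an at least 90-fold higher number from compound 1 to compound 2 (1.95 log units; beyond the scatter), is large and alters the same 4,6-diamino-5-(dimethylamino)pyrimidin-2-yl group, though it ends at a limit and its true size is unknown. A higher number is therefore expected here, but a smaller step. The expected step is a 2.7-fold higher number from compound 1 to compound 3 (0.44 log units; beyond the scatter). Compound 3 is estimated at 3000 nM, with an expected range from 600 nM to 20000 nM.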

Compound 3, half-maximal effective concentration: 4900 nM
Beside the measured number, compound 3's estimate is 1.6-fold (0.21 log units) below it; the range from low to high includes it.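

Replacing the 4,6-diamino-5-(dimethylamino)pyrimidin-2-yl group with the group carrying one five-membered and one six-membered aromatic ring gives, in this assay, a 4.5-fold higher number from compound 1 to compound 3 (0.65 log units; beyond the scatter). Among these compounds, this is the first step at this position with a true number at both ends, and it is modest, with hydrogen-bond donor and acceptor counts unchanged. Compound 2 remains a limit, not a number: the limit of > 100000 nM in this assay, at which 1 of the 3 values shown sits.

The compounds shown do not separate the contributions of the added ring and its carbonyl. On these data alone, how methylamino or pyrrolidin-1-yl would read in place of dimethylamino also stays open.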